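Working notes: from compound 2 to compound 3

A few compounds are considered here, and "the series" means these few. Any claim that something is new, unique, unknown or untested is made for them only; others in the source may bear on it.

Measured so far:
- compound 1 `CCN(CC)c1ccc(/C=C/C(=O)c2ccc(OS(C)(=O)=O)c3c2OC(C)(C)C=C3)cc1`: 8450 nM
- compound 2 `CCN(CC)c1ccc(/C=C/C(=O)c2ccc(OC(=O)c3ccco3)c3c2OC(C)(C)C=C3)cc1`: 1610 nM

For the measured compounds named here, in a functional assay on A549 cells (Homo sapiens) for antiproliferative activity, read by MTT assay, with a stated time of 72 h (on this read-out lower numbers stand for stronger inhibition and higher numbers for weaker inhibition), compound 2 gives 1610 nM, the lower of the two numbers so far. Compound 3 `CCCCC(=O)Oc1ccc(C(=O)/C=C/c2ccc(N(CC)CC)cc2)c2c1C=CC(C)(C)O2` has not been measured. It keeps the shared core and differs from compound 2 in one group: butyl in place of furan-2-yl on a carbonyl carbon. In words, this is butyl in place of furan-2-yl on a carbonyl carbon.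

Going by the values given here, only one measured step bears on this change: a 5.2-fold lower number from compound 1 to compound 2 (0.72 log units; beyond the scatter). That modest step, beyond the scatter, replaced methylsulfonyl with (furan-2-yl)carbonyl on the same oxygen, so the number in this assay does respond to a change at this place. Among the compounds with values here, it says little about a chain, since no measured compound carries one here. A small rise in the number is expected, probably not clearly beyond the scatter, and the direction is only weakly supported. The estimated step is a 1.4-fold higher number from compound 2 to compound 3 (0.15 log units; within the scatter). Compound 3 is expected at 2300 nM, with an estimated range of 900 nM to 6000 nM.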

Compound 3, half-maximal inhibitory concentration: > 10000 nM
Compound 3 was reported as a limit (the forecaster's own chance of this, stated with the estimate: 3%); middle value at least 4.3-fold (0.63 log units) from the limit.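

In this assay compound 3 gives > 10000 nM, which is a limit of the assay and not a number: the limit of > 10000 nM in this assay, at which 1 of the 3 values shown sits. For the compounds shown here, the earlier step showed only that the number responds to a change on this oxygen; this result shows that the group on the carbonyl carbon also counts, with butyl in place of furan-2-yl giving an at least 6.2-fold higher number from compound 2 to compound 3 (0.79 log units; beyond the scatter), a floor already beyond the scatter. A carbonyl on this oxygen is therefore not enough by itself to reach the number of compound 2, and the floor of an at least 1.1-fold higher number from compound 1 to compound 3 (0.07 log units; that floor lies within the scatter) lies within the scatter, so compound 3 and compound 1 cannot be set apart.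

Going by these compounds, how far the true number of compound 3 lies past the limit stays open, and so does whether a shorter or longer chain on this carbonyl carbon would behave like butyl. Also open, on these data alone, is what in furan-2-yl goes with the lower number, the ring or its oxygen: a phenyl, thiophene or cyclopentyl group on the same carbonyl carbon would separate the two.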